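The source may report more compounds than this note shows. Statements on the series, on what has been measured and on what is new or still open speak of the compounds shown alone.

Working notes on the series

Three compounds share one core: compound 1 `CO[C@H]1C[C@H](O[Si](C)(C)C(C)(C)C)O[C@@H](C)/C1=C\C(=O)O`, compound 2 `CO[C@H]1C[C@H](O[Si](C)(C)C(C)(C)C)O[C@@H](C)/C1=C/CO` and compound 3 `C=CCOC(=O)/C=C1/[C@H](C)O[C@@H](O[Si](C)(C)C(C)(C)C)C[C@@H]1OC`. In a functional assay on the whole organism for inhibition, with Artemia salina as the target (a higher number here means a weaker inhibitor of growth, a lower number a stronger inhibitor of growth), compound 1 gives 0.002 ug/mL. In this assay compound 2 gives 0.01 ug/mL. In this assay compound 3 gives 0.002 ug/mL, the same figure as compound 1 at the digits shown, and these two values are together the lowest of the three; no step between compound 1 and compound 3 has been computed, so only the agreement of their values is noted. Within the data shown here, the single measured step within one change is a number 2.3 two-fold dilutions lower from compound 2 to compound 3 (beyond the scatter).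

Compound 4 `CO[C@H]1C[C@H](O[Si](C)(C)C(C)(C)C)O[C@@H](C)/C1=C/C=O` differs from compound 3 by hydrogen in place of allyloxy on a carbonyl carbon; cut one bond further out this reads allyloxycarbonyl to formyl. The carbonyl stays. The step from compound 2 to compound 3 bears on it only loosely, since that change touched the whole chain end. Compound 4 is expected to give 0.004 ug/mL, within 0.0015 ug/mL to 0.012 ug/mL, which means an expected step of a number one two-fold dilution higher from compound 3 to compound 4 (within the scatter), small, upward if at all.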

Compound 4, minimum inhibitory concentration: 0.01 ug/mL
Estimate against measurement, compound 4: 1.3 two-fold dilutions below; measured number inside the range.
By their numbers in this assay, from the lowest: compounds 1 and 3 (each within the scatter of the next); then compounds 2 and 4 (each within the scatter of the next).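

In this assay, hydrogen in place of allyloxy on a carbonyl carbon gives a number 2.3 two-fold dilutions higher from compound 3 to compound 4 (beyond the scatter), so the carbonyl alone, which stays in this change, does not keep the value at the level of compound 3. Formyl in place of hydroxymethyl on a double-bonded chain carbon bound to a double-bonded ring carbon gives no change at the digits printed from compound 2 to compound 4 (within the scatter), so these two chain ends cannot be told apart in this read-out. Nothing available accounts for either result.

From the compounds shown here alone, whether the lower value of compound 3 belongs to the allyl part in particular or would also appear with a methyl ester or a longer alkyl ester remains open. The compounds shown also do not say how an amide or an amine at this chain end would compare with compound 3.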